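From dimethylamino to formyl: compound 3 to compound 4

The source may hold more compounds than are shown below. What is called first, only, known or untested is meant among the compounds shown, and "the series" means these compounds.

Values in a functional assay on SKW3 cells (Homo sapiens) for antiproliferative activity, read by WST assay, with a stated time of 3 days (on this read-out higher numbers stand for weaker inhibition and lower numbers for stronger inhibition), are as follows:
compound 1 `O=c1cc(I)n([C@@H]2O[C@H](CO)[C@@H](O)[C@H]2O)c(=O)[nH]1` gives 18900 nM
compound 2 `Nc1cc(=O)[nH]c(=O)n1[C@@H]1O[C@H](CO)[C@@H](O)[C@H]1O` gives > 50000 nM as a limit
compound 3 `CN(C)c1cc(=O)[nH]c(=O)n1[C@@H]1O[C@H](CO)[C@@H](O)[C@H]1O` gives > 50000 nM as a limit
compound 4 `O=Cc1cc(=O)[nH]c(=O)n1[C@@H]1O[C@H](CO)[C@@H](O)[C@H]1O` is not yet measured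

Compound 3 stands at the limit of > 50000 nM in this assay, at which 2 of the 3 values shown sit, and so holds a limit, not a number. The change to compound 4 puts formyl in place of dimethylamino on an aromatic carbon, next to the ring nitrogen, and the full count is formyl in place of dimethylamino on an aromatic carbon for this exchange.

Three measured steps exchange a group at this place. Iodo gives way to amino in an at least 2.6-fold higher number from compound 1 to compound 2 (0.42 log units; beyond the scatter) and to dimethylamino in an at least 2.6-fold higher number from compound 1 to compound 3 (0.42 log units; beyond the scatter) with both sizes known only as bounds. The third is a step that the two limits leave unreadable from compound 2 to compound 3 and yields no size. Among the compounds with values here, the only number comes from compound 1 at 18900 nM and sets the reference for a readable result.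

Formyl has no measured counterpart here, so the direction is only weakly supported. Compound 4 is expected to stay weak in this assay with at best a small move towards a lower number, and a reported limit is slightly more likely than a number. The expected size is an at least 1.2-fold lower number from compound 3 to compound 4 (0.09 log units; that floor lies within the scatter) as estimated from these values. For compound 4 the estimate is 40000 nM with an expected range from 12000 nM to 80000 nM in this series.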

Compound 4, half-maximal inhibitory concentration: > 50000 nM
Compound 4 gave a limit, no number; the forecaster's own chance of this, stated with the estimate: 55%; middle value at least 1.2-fold (0.09 log units) from the limit.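

In this assay compound 4 gives > 50000 nM, which is a limit and not a number. Formyl in place of iodo on the aromatic carbon next to the ring nitrogen gives an at least 2.6-fold higher number from compound 1 to compound 4 (0.42 log units; beyond the scatter), so a carbon-linked carbonyl group now joins the two nitrogen-linked groups, amino and dimethylamino, in falling short of iodo, the only group at this place with a readable value so far. The steps among compound 2, compound 3 and compound 4 cannot be read, and the series now gathers at one limit with compound 1 as the sole exception: the limit of > 50000 nM in this assay, at which 3 of the 4 values shown sit.

As far as these compounds go, whether amino, dimethylamino and formyl differ from one another at all stays open, since no size can be given for any exchange among them. Also open, from the compounds shown here alone, is whether the number held by compound 1 belongs to iodo alone or extends to other halogens such as bromo or chloro, and whether a carboxylic acid or a hydroxymethyl group at this place would give a readable value.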